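Swapping the Neopentyl End for an Alkenyl End

A few compounds are considered here, and "the series" means these few. Any claim that something is new, unique, unknown or untested is made for them only; others in the source may bear on it.

Measured in a functional assay on HCT-15 cells (Homo sapiens) for antiproliferative activity, read by sulforhodamine B assay; on this read-out higher numbers stand for weaker inhibition of growth and lower numbers for stronger inhibition of growth:
- Compound 1 `CC(C)CCCOc1cccc(O)c1C(=O)/C=C/c1ccc(O)cc1`: 11600 nM
- Compound 2 `CCCCCCOc1cccc(O)c1C(=O)/C=C/c1ccc(O)cc1`: > 30000 nM, a limit of the assay
- Compound 3 `CC(C)(C)CCOc1cccc(O)c1C(=O)/C=C/c1ccc(O)cc1`: 3430 nM

Compound 3 has the lowest number of the series, and compound 1 is its nearest neighbour. The value of compound 2 is a limit, not a number.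

Compound 4 `CC(C)=CCOc1cccc(O)c1C(=O)/C=C/c1ccc(O)cc1` differs from compound 3 as follows: 2-methylprop-1-en-1-yl in place of neopentyl on a saturated chain carbon bound to an oxygen on an aromatic ring. The 3,3-dimethylbutoxy group thus becomes (3-methylbut-2-en-1-yl)oxy.

Within the data shown here, two measured steps bear on this change, a 3.4-fold lower number from compound 1 to compound 3 (0.53 log units; beyond the scatter) and an at least 8.7-fold lower number from compound 2 to compound 3 (0.94 log units; beyond the scatter). Both show that this assay responds to the chain end, but neither introduces a double bond. Compound 4 has a branched chain end, as do compound 1 and compound 3, so a change as large as the one from the hexyl chain of compound 2 is not expected. A small rise in the number is expected, probably within the scatter. This expectation amounts to a 1.6-fold higher number from compound 3 to compound 4 (0.21 log units; within the scatter). For compound 4 the estimated value is 5500 nM, with an expected range of 1800 nM to 16000 nM.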

Compound 4, concentration for 50% growth inhibition: > 30000 nM
Compound 4 ended at the assay's limit; the forecaster's own chance of this, stated with the estimate: 7%; at least 5.4-fold (0.73 log units) between middle value and limit.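

In this assay, a branched chain end alone does not keep the number low at this position: 2-methylprop-1-en-1-yl in place of neopentyl gives an at least 8.7-fold higher number from compound 3 to compound 4 (0.94 log units; beyond the scatter). Set against the chain of compound 1, the same end gives an at least 2.5-fold higher number from compound 1 to compound 4 (0.41 log units; beyond the scatter), so among the branched ends, compound 4 goes against the lower numbers of compound 1 and compound 3. Compound 4 gives > 30000 nM, which is a limit of the assay.

From the compounds shown here alone, the step from compound 2 to compound 4 cannot be read, and their order stays open: the limit of > 30000 nM in this assay, at which 2 of the 4 values shown sit. The change also swaps neopentyl for a group that has fewer carbons and a double bond, so a saturated 3-methylbutyl chain would be needed to tell these two differences apart.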